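Indolyl in Place of Chlorophenyl on the Amine Nitrogen

A few compounds are considered here, and "the series" means these few. Any claim that something is new, unique, unknown or untested is made for them only; others in the source may bear on it.

Compound 1 `O=C(/C=C\Nc1ccc(F)cc1)c1nc(-c2ccc(F)cc2)n2ccccc12`: in a functional assay on HCT-116 cells (Homo sapiens) for cytotoxicity, read by MTT assay, with a stated time of 48 h (a higher number here means a weaker inhibitor, a lower number a stronger inhibitor), compound 1 gives only the limit > 30000 nM.
Compound 2 `COc1ccc(N/C=C\C(=O)c2nc(-c3ccc(F)cc3)n3ccccc23)cc1`: in this assay compound 2 likewise gives only the limit > 30000 nM.
Compound 3 `O=C(/C=C\Nc1ccc(Cl)cc1)c1nc(-c2ccc(F)cc2)n2ccccc12`: in this assay compound 3 gives 1210 nM.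

For the measured compounds named here, compound 3 thus carries the only number among the three values; the other two sit at a limit of the assay, (the limit of > 30000 nM in this assay, at which 2 of the 3 values shown sit). The step of an at least 24-fold lower number from compound 1 to compound 3 (1.39 log units; beyond the scatter) and the step of an at least 24-fold lower number from compound 2 to compound 3 (1.39 log units; beyond the scatter) are both large. The step from compound 1 to compound 2 is left unreadable by the two limits. Compound 4 `Cc1cc2cc(N/C=C\C(=O)c3nc(-c4ccc(F)cc4)n4ccccc34)ccc2[nH]1` differs from compound 3 by 2-methyl-1H-indol-5-yl in place of 4-chlorophenyl on an amine nitrogen. Going by the values given here, none of the measured steps covers this kind of change; they show only that the group on this nitrogen moves the number by large amounts. The expected step of a 2.5-fold higher number from compound 3 to compound 4 (0.39 log units; beyond the scatter) is therefore uncertain. Compound 4 is estimated at 3000 nM, between 400 nM and 30000 nM.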

Compound 4, half-maximal inhibitory concentration: > 30000 nM
Compound 4 ended at the assay's limit (the forecaster's own chance of this, stated with the estimate: 25%); at least 10-fold (1.00 log units) between middle value and limit.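

Putting 2-methyl-1H-indol-5-yl in place of 4-chlorophenyl on the amine nitrogen gives an at least 24-fold higher number from compound 3 to compound 4 (1.39 log units; beyond the scatter) in this assay. The earlier steps shown here covered only substituted phenyl groups, whereas this one shows that a group with a second aromatic ring and a hydrogen-bond donor does not keep the number of compound 3. The steps among compound 1, compound 2 and compound 4 cannot be read, and 4-chlorophenyl remains the only group here with a number: the limit of > 30000 nM in this assay, at which 3 of the 4 values shown sit.

As far as these compounds go, it remains open whether the second ring, the methyl or the ring hydrogen accounts for this step. A 4-bromophenyl or an unmethylated 1H-indol-5-yl group would help separate these.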